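Removing a Hydroxy Group from a Shared Core

This account rests on a few compounds, and the source may have more. Where it says the series, first, only, none or still open, it means among the compounds named here.

Measured so far in a functional assay on HL-60 cells (Homo sapiens) for cytotoxicity, read by MTT assay, with a stated time of 48 h; on this read-out lower numbers stand for stronger inhibition and higher numbers for weaker inhibition:
Compound 1 `COc1ccc2[nH]c(-c3ccc(C)[se]3)cc(=O)c2c1O`, with compound 1 giving 400 nM.
Compound 2 `COc1ccc2[nH]c(-c3ccc(C)[se]3)cc(=O)c2c1`, with compound 2 giving 400 nM.
Compound 3 `COc1ccc2[nH]c(-c3cc[se]c3)cc(=O)c2c1O`, with compound 3 giving 400 nM.

Compounds 1 and 2 share a core and differ only by hydrogen in place of hydroxy on an aromatic carbon; the step of no change at the digits printed from compound 1 to compound 2 (within the scatter) shows this change made no difference within the scatter. The cores of compounds 1 and 3 differ by a group of 5 heavy atoms (4 carbon, 1 selenium; one five-membered aromatic ring with 1 hetero atom) in place of a group of 6 heavy atoms (5 carbon, 1 selenium; one five-membered aromatic ring with 1 hetero atom), on an aromatic carbon, and compound 3 stands level with compound 1 in this assay.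

Compound 4 `COc1ccc2[nH]c(-c3cc[se]c3)cc(=O)c2c1` has not been measured. It relates to compound 3 by hydrogen in place of hydroxy on an aromatic carbon, the same change as from compound 1 to compound 2, at an identical place. Because no change at the digits printed from compound 1 to compound 2 (within the scatter) was flat, the step of no change at the digits printed from compound 3 to compound 4 (within the scatter) is expected to be flat as well, so compound 4 is estimated at 400 nM.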

Compound 4, half-maximal inhibitory concentration: 700 nM
Estimate against measurement, compound 4: 1.8-fold (0.24 log units) below; measured number inside the range.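

In this assay, replacing the hydroxy group with hydrogen gives a 1.8-fold higher number from compound 3 to compound 4 (0.24 log units; within the scatter), and this agrees with the same change on the other core: the same change on two cores in this assay, no change at the digits printed (within the scatter) from compound 1 to compound 2 and a 1.8-fold higher number (0.24 log units; within the scatter) from compound 3 to compound 4, 1.8-fold (0.24 log units) apart, within the scatter of two such steps. Exchanging the selenium-containing aromatic ring group of compound 2 for that of compound 4 gives a 1.8-fold higher number from compound 2 to compound 4 (0.24 log units; within the scatter), and this also agrees with the earlier step: the same change on two cores in this assay, no change at the digits printed (within the scatter) from compound 1 to compound 3 and a 1.8-fold higher number (0.24 log units; within the scatter) from compound 2 to compound 4, 1.8-fold (0.24 log units) apart, within the scatter of two such steps. So both changes carried from one core to the other within the scatter, but two small steps on two cores do not show that either change is without effect or that it would carry to further cores.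

The compounds shown leave open whether an amine in place of the hydroxy group would shift the result beyond the scatter. They also leave open what a longer chain in place of the methoxy group would do.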